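A few compounds are considered here, and "the series" means these few. Any claim that something is new, unique, unknown or untested is made for them only; others in the source may bear on it.

Measured so far:
- compound 1 `CCCn1c(=O)c2nc(C(C)N)[nH]c2n(CCC)c1=O` — 3000 nM
- compound 2 `CCCn1c(=O)c2nc(C(c3ccccc3)C3CC3)[nH]c2n(CCC)c1=O` — 150 nM

In an assay on cell membranes for binding affinity to adenosine receptor A1 (Cavia porcellus) (a lower number here means a stronger inhibitor, a higher number a weaker inhibitor), compound 1 gives 3000 nM and compound 2 gives 150 nM. Compound 2 stands lowest of the two numbers; compound 1 is the higher, and the gap between them lies beyond the scatter. Compound 3 `CCCn1c(=O)c2nc(C(c3ccc(F)cc3)C3CC3)[nH]c2n(CCC)c1=O` differs from compound 2 by fluoro in place of hydrogen on an aromatic carbon — fluoro in place of hydrogen on an aromatic carbon. For the measured compounds named here, no measured pair shows this change, so there is no step to lean on. The step of no change at the digits printed from compound 2 to compound 3 (within the scatter) is expected to be small, in no firm direction, and most likely within the scatter. Compound 3 is accordingly estimated at 150 nM, with a range from 60 nM to 400 nM.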

Compound 3, inhibition constant: 250 nM
The estimate for compound 3 lay 1.7-fold (0.22 log units) below the measured number, within the range that was stated.
By their numbers in this assay, from the lowest: compounds 2 and 3 (each within the scatter of the next); then compound 1.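

In this assay, phenyl to 4-fluorophenyl gives a 1.7-fold higher number from compound 2 to compound 3 (0.22 log units; within the scatter). For the compounds shown here, this carbon of the aromatic ring, para to a large group, therefore takes fluoro in place of hydrogen with no step beyond the scatter, a first reading for this position that compound 1 could not give. It remains a single pair and a single substituent, so it sets no trend for the position. Nothing available bears on the reason for this result.
Open, on these data alone, is how a chlorine atom, a methoxy group or an amine at this same carbon would read. A single fluoro leaves the tolerance of this position for larger groups unsettled.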